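Rat Oral Exposure: Projecting the Pyrrolidinyl Analogue

This account rests on a few compounds, and the source may have more. Where it says the series, first, only, none or still open, it means among the compounds named here.

Compound 1 `Cc1cn2c(-c3cn[nH]c3)cnc2c(Nc2cc(Cc3ccccn3)ns2)n1` gives the highest number of the three compounds measured in an ADME assay on the whole organism for pharmacokinetics, with Rattus norvegicus as the target, with a stated time of 6 h, at a dose of 10 mg/kg by the oral route (on this read-out higher numbers stand for higher exposure at the dose given and lower numbers for lower exposure), with a value of 6880 ng.h/mL. Compound 2 `COc1cccc(Cc2cc(Nc3nc(C)cn4c(-c5cn[nH]c5)cnc34)sn2)n1` gives 2300 ng.h/mL in this assay, and compound 3 `Cc1cn2c(-c3cn[nH]c3)cnc2c(Nc2cc(Cc3cccc(C(=O)N4CCCCC4)n3)ns2)n1` gives 50 ng.h/mL. The step from compound 1 to compound 2 is a 3.0-fold lower number from compound 1 to compound 2 (0.48 log units; beyond the scatter); the step from compound 1 to compound 3 is a 140-fold lower number from compound 1 to compound 3 (2.14 log units; beyond the scatter). Between the two substituted compounds the step is a 46-fold lower number from compound 2 to compound 3 (1.66 log units; beyond the scatter). Both additions to compound 1 sit on an aromatic carbon, and both lower the number, the carbonyl-linked ring far more than the methoxy.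

Compound 4 `Cc1cn2c(-c3cn[nH]c3)cnc2c(Nc2cc(C(c3ccccn3)N3CCCC3)ns2)n1` is not yet measured. It differs from compound 1 by pyrrolidin-1-yl in place of hydrogen on a saturated chain carbon bound to two aromatic carbons. Among the measured compounds shown here, no measured step places a group on this saturated chain carbon, so the two aromatic-carbon steps are the only guide. Each added group lowered exposure, one modestly and one greatly; the new ring is larger than methoxy and smaller than the carbonyl-linked ring, and on that basis a lower number in this assay is expected for compound 4, of a size between the two measured steps. Compound 4 is therefore estimated at 800 ng.h/mL in this assay, within 150 ng.h/mL to 4000 ng.h/mL. From compound 1 this estimate means an 8.6-fold lower number from compound 1 to compound 4 (0.93 log units; beyond the scatter).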

Compound 4, area under the concentration-time curve: 9.15 ng.h/mL
Compound 4: middle estimate off by 87-fold (1.94 log units), on the high side; the whole stated range lies above it.
By their numbers in this assay, from the lowest: compound 4; then compound 3; then compound 2; then compound 1.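

Pyrrolidin-1-yl in place of hydrogen on the saturated chain carbon bound to two aromatic carbons gives the first measured step at this carbon in this assay and shows that the position tolerates this change poorly: a 750-fold lower number from compound 1 to compound 4 (2.88 log units; beyond the scatter) is what the change costs. This is the largest step from compound 1 in the series, larger than a 140-fold lower number from compound 1 to compound 3 (2.14 log units; beyond the scatter) on an aromatic carbon, even though pyrrolidin-1-yl is the smaller of the two entering rings, so the size of the entering group does not order the steps from compound 1 once this position is included. No measurement shown here bears on what lies behind the fall in exposure.

As far as these compounds go, whether any group on this saturated chain carbon gives a step of this size remains open, as a methyl group, a hydroxyl group or a small open-chain amine such as dimethylamino at the same carbon would show how much of the step belongs to the pyrrolidine ring itself. Also open, from the compounds shown here alone, is whether pyrrolidin-1-yl at this carbon gives a step of similar size when the methoxy group of compound 2 is present.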